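Trimming the allyl on sulfur to a methyl

The source may report more compounds than this note shows. Statements on the series, on what has been measured and on what is new or still open speak of the compounds shown alone.

Compound 1 `CCCc1nnc(SC)n1N1C(=O)c2ccccc2C1=O` gives > 200000 nM in a functional assay on A549 cells (Homo sapiens) for cytotoxicity, read by MTT assay, with a stated time of 48 h (on this read-out lower numbers stand for stronger inhibition and higher numbers for weaker inhibition), which is a limit of the assay rather than a number.
Compound 2 `C=CCSc1nnc(-c2cc(OC)c(OC)c(OC)c2)n1N1C(=O)c2ccccc2C1=O` gives > 200000 nM in this assay, likewise a limit.

Going by the values given here, compound 2 therefore stands at a limit, and the only other value shown is a limit too; both sit at the limit of > 200000 nM in this assay, at which 2 of the 2 values shown sit. Among the compounds with values here, no pair of measured compounds differs in a single place, so no measured step is available to set a scale. Compound 3 `COc1cc(-c2nnc(SC)n2N2C(=O)c3ccccc3C2=O)cc(OC)c1OC` differs from compound 2 by hydrogen in place of vinyl on a saturated chain carbon bound to a sulfur. Within the data shown here, with both measured compounds at the limit and no measured step to lean on, no shift beyond the scatter is expected in this assay, in either direction. The estimate for compound 3 is 250000 nM, with a range from 100000 nM to 600000 nM, most likely reported again as a limit. The step this estimate means, a step that the limit leaves unreadable from compound 2 to compound 3, is expected to lie within the scatter.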

Compound 3, half-maximal inhibitory concentration: > 200000 nM
Compound 3 ended at the assay's limit; the forecaster's own chance of this, stated with the estimate: 80%; the middle value is on the limit's open side.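

Compound 2 and compound 3 both stand at a limit of this assay, so no step can be read from the change of allyl to methyl. The compounds shown leave open how strongly any of them acts, and whether that change matters at all, since all share one limit: the limit of > 200000 nM in this assay, at which 3 of the 3 values shown sit.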